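A few compounds are considered here, and "the series" means these few. Any claim that something is new, unique, unknown or untested is made for them only; others in the source may bear on it.

Compound 1 `CNc1nc(N)c2nc(O)n(Cc3ccccc3)c2n1` and compound 2 `CCOc1nc(N)c2nc(O)n(Cc3ccccc3)c2n1` share one core and differ at a single aromatic carbon. In a functional assay (spleen, spleen) for activation, with Mus musculus as the target (on this read-out lower numbers stand for an effect already at smaller amounts and higher numbers for an effect only at larger amounts of compound), compound 1 gives 1 uM, while compound 2 gives 0.1 uM, a step of a 10-fold lower number from compound 1 to compound 2 (1.00 log units; beyond the scatter). Compound 2 therefore carries the lowest number of the two measured, with compound 1 the nearest. Compound 3 `CCCCSc1nc(N)c2nc(O)n(Cc3ccccc3)c2n1` alters compound 2 by butylsulfanyl in place of ethoxy on an aromatic carbon. For the measured compounds named here, no measured step exchanges ethoxy for butylsulfanyl, and the one step known, between methylamino and ethoxy, does not bear directly on it, so only a modest shift is expected. Compound 3 is estimated at 0.3 uM, between 0.03 uM and 3 uM, an expected step of a 3.0-fold higher number from compound 2 to compound 3 (0.48 log units; beyond the scatter).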

Compound 3, minimum effective concentration: 0.01 uM
Compound 3: the middle estimate sits 30-fold (1.48 log units) above what was measured, and the stated range ends above it.
By their numbers in this assay, from the lowest: compound 3; then compound 2; then compound 1.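

At this aromatic carbon, the ethoxy group is not the limit: butylsulfanyl in its place gives a 10-fold lower number from compound 2 to compound 3 (1.00 log units; beyond the scatter) in this assay. Measured against the methylamino group, the same butylsulfanyl group gives a 100-fold lower number from compound 1 to compound 3 (2.00 log units; beyond the scatter), so this one position can move the read-out widely while the shared core stays the same. No measurement here explains why the number falls.

This change swaps oxygen for sulfur and lengthens the chain together, so the compounds shown cannot separate the two effects; butoxy and ethylsulfanyl would pull them apart. From the compounds shown here alone, whether a longer chain, such as hexylsulfanyl, lowers the number further remains open.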